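Piperidin-1-yl in Place of Thiomorpholin-4-yl at the Thiocarbonyl

The source may hold more compounds than are shown below. What is called first, only, known or untested is meant among the compounds shown, and "the series" means these compounds.

Three compounds have been measured in a functional assay on HeLa cells (Homo sapiens) for cytotoxicity, read by MTT assay, with a stated time of 72 h, tested at 30 uM; a higher number here means more inhibition of growth at the concentration tested, a lower number less inhibition of growth:
compound 1 `N/C(=N\NC(=S)N1CCN(c2ccccn2)CC1)c1ccc(F)cn1` gives 87%;
compound 2 `Cc1ccnc(/C(N)=N/NC(=S)N2CCSCC2)c1` gives 78.3%;
compound 3 `N/C(=N\NC(=S)N1CCSCC1)c1ccccn1` gives 80.6%.

Compound 2 holds the lowest of these three numbers, yet all three lie within the usual scatter of one another, so no order among them can be read from the figures. Among the compounds with values here, the only step between two compounds that differ in a single place is a number 2.3 percentage points higher from compound 2 to compound 3 (within the scatter), where the change is hydrogen in place of methyl on an aromatic carbon. Compound 1 shares no single-point difference with compound 2; its number simply sits within the scatter of that of compound 2.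

The unmeasured compound 4 `Cc1ccnc(/C(N)=N/NC(=S)N2CCCCC2)c1` differs from compound 2 at a different place: piperidin-1-yl in place of thiomorpholin-4-yl on a thiocarbonyl carbon. Within the data shown here, none of the measured steps touches the ring attached to the thiocarbonyl carbon, and the one step that is known, a number 2.3 percentage points higher from compound 2 to compound 3 (within the scatter), was within the scatter. There is therefore no measured basis for expecting the growth inhibition to move beyond the scatter in either direction, and the expected step of a number 0.3 percentage points lower from compound 2 to compound 4 (within the scatter) is taken as essentially flat. For compound 4 the estimated value in this assay is 78%, with a range from 64% to 90%.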

Compound 4, percent growth inhibition at one concentration: 69.1%
Beside the measured number, compound 4's estimate is 8.9 percentage points above it, and the stated range covers the measured number.
By their numbers in this assay, from the lowest: compounds 4, 2, 3 and 1 (each within the scatter of the next, the first and the last beyond it).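

Within the data shown here, this is the first measured change to the ring on the thiocarbonyl carbon: in this assay, piperidin-1-yl in place of thiomorpholin-4-yl gives a number 9.2 percentage points lower from compound 2 to compound 4 (within the scatter). A ring with one hetero atom and no hydrogen-bond acceptor can therefore replace one with two hetero atoms and one acceptor, with no difference that can be told apart from the ordinary variation between repeated measurements, so this pair gives no sign that the ring sulfur is needed for growth inhibition at the tested concentration. No supporting data are available that could account for the size of this step.

The compounds shown leave open how morpholin-4-yl, which has oxygen in its ring, or an open-chain diethylamino group would behave on the same thiocarbonyl carbon. They also leave open whether the exchange of thiomorpholin-4-yl for piperidin-1-yl would give a similar result with hydrogen in place of methyl on the aromatic carbon, as in compound 3, and whether differences would appear across a full range of concentrations.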